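The compounds below may be only part of what the source reports. "The series", "measured", "known", "first", "only" and "open" are said of these compounds alone.

Measured compounds in a functional assay on HT-29 cells (Homo sapiens) for cytotoxicity, read by MTT assay, with a stated time of 72 h; a higher number here means a weaker inhibitor, a lower number a stronger inhibitor:
- compound 1 `COc1cc2c(Oc3ccc(NC(=O)c4cn(-c5ccccc5OC(F)(F)F)cn4)cc3F)ccnc2cc1OCCCN1CCCCC1`: 250 nM
- compound 2 `COc1cc2c(Oc3ccc(NC(=O)c4cn(-c5ccc(Cl)cc5Cl)cn4)cc3F)ccnc2cc1OCCCN1CCCCC1`: 4300 nM

Compound 1 holds the lower of the two numbers; compound 2 is separated from it by a 17-fold higher number from compound 1 to compound 2 (1.24 log units; beyond the scatter), a change of the group on the aromatic nitrogen.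

Compound 3 `COc1cc2c(Oc3ccc(NC(=O)c4cn(-c5ccccc5OC(F)(F)F)cn4)cc3F)ccnc2cc1OCCCN1CCC(C)CC1` differs from compound 1 by methyl in place of hydrogen on a saturated ring carbon, piperidin-1-yl becoming 4-methylpiperidin-1-yl. For the measured compounds named here, the only measured step, a 17-fold higher number from compound 1 to compound 2 (1.24 log units; beyond the scatter), concerns a different part of the molecule, so no measured step bears directly on this change. Going by the values given here, nothing among the measured compounds points to a step beyond the scatter, and the expectation for compound 3 in this assay is therefore a number close to that of compound 1. Compound 3 is estimated at 250 nM, with a range from 100 nM to 700 nM, which is expected to amount to no change at the digits printed from compound 1 to compound 3 (within the scatter).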

Compound 3, half-maximal inhibitory concentration: 690 nM
For compound 3 the middle estimate is 2.8-fold (0.44 log units) below the measured one; the range from low to high includes it.
By their numbers in this assay, from the lowest: compound 1; then compound 3; then compound 2.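

In this assay the saturated ring at the end of the side chain proves able to move the number: piperidin-1-yl becoming 4-methylpiperidin-1-yl gives a 2.8-fold higher number from compound 1 to compound 3 (0.44 log units; beyond the scatter), towards a weaker inhibitor, from a single added methyl three ring bonds from the ring nitrogen. For the compounds shown here, the earlier step concerned only the group on the aromatic nitrogen, so this is the first sign that the far end of the molecule also bears on this read-out. Nothing shown here gives a reason for this step.

As far as these compounds go, whether other groups on this ring carbon act in the same way stays open, and a hydroxyl or an ethyl there, or a morpholine in place of the piperidine, would test this. From the compounds shown here alone, it is also open whether the methyl would have a similar effect alongside the 2,4-dichlorophenyl group of compound 2.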